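This account rests on a few compounds, and the source may have more. Where it says the series, first, only, none or still open, it means among the compounds named here.

Compound 2 `CSc1cc(C)nc(SC)c1NC(=O)N(Cc1ccc(Oc2ccc(F)cc2)cc1)C1CCCCC1` gives 23 nM in an assay for inhibition of acyl-CoA:cholesterol acyltransferase (Oryctolagus cuniculus), using microsomes; on this read-out lower numbers stand for stronger inhibition and higher numbers for weaker inhibition. Compound 1 `Cc1cc(S(C)(=O)=O)c(NC(=O)N(Cc2ccc(Oc3ccc(F)cc3)cc2)C2CCCCCC2)c(S(C)(=O)=O)n1` gives 45 nM in this assay; the two numbers lie within the scatter of each other, so neither stands apart. Compound 3 `CSc1cc(C)nc(SC)c1NC(=O)N(CCCc1ccccc1)Cc1ccc(Oc2ccc(F)cc2)cc1` differs from compound 2 by 3-phenylpropyl in place of cyclohexyl on an amide-type nitrogen. Going by the values given here, no measured pair covers this change, so its size is not known from the series; at most a shift of roughly the width of the scatter, toward a weaker number, is expected. For compound 3 the estimate is 60 nM, with a range from 15 nM to 250 nM. The expected step is a 2.6-fold higher number from compound 2 to compound 3 (0.42 log units; beyond the scatter).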

Compound 3, half-maximal inhibitory concentration: 28 nM
For compound 3 the middle estimate is 2.1-fold (0.33 log units) above the measured one; low and high end bracket the measured number.
By their numbers in this assay, from the lowest: compounds 2, 3 and 1 (each within the scatter of the next).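

In this assay the exchange of cyclohexyl for 3-phenylpropyl on the amide-type nitrogen gives a 1.2-fold higher number from compound 2 to compound 3 (0.09 log units; within the scatter), so this nitrogen carries either a saturated ring or an open chain ending in an aromatic ring with no step beyond the scatter. This is a single pair on one core, and no evidence on hand bears on the result. Still open, as far as these compounds go, is whether a longer chain such as 5-phenylpentyl, or a chain ending in an amine or a carboxylic acid, holds the number at this nitrogen. From the compounds shown here alone, the same exchange on the core of compound 1 also remains open.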